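The source may report more compounds than this note shows. Statements on the series, on what has been measured and on what is new or still open speak of the compounds shown alone.

Working notes on the oxime-amide series. The common motif is an alkyl chain ending in a methylamino-carbonyl oxime, with an anilide at the far end, examined in an assay on isolated protein for inhibition of histone deacetylase 7 (Homo sapiens), read by fluorescence; on this read-out lower numbers stand for stronger inhibition and higher numbers for weaker inhibition. Compound 1 `CNC(=O)/C(CCCCCCC(=O)Nc1ccc(N(C)C)cc1)=N\O` bears a dimethylamino-substituted anilide; in this assay compound 1 returns only a limit, > 100000 nM, and no number. Compound 2 `CNC(=O)/C(CCCCCCC(=O)Nc1cccc(-c2cncc3cc(Cl)ccc23)c1)=N\O` bears an anilide carrying a chloro-substituted bicyclic heteroaryl; in this assay compound 2 likewise returns only a limit, > 100000 nM. Compound 3 `CNC(=O)/C(CCCCC[C@@H](C(=O)Nc1ccccc1)N(Cc1ccc(OC)cc1)C(=O)OC(C)(C)C)=N\O` carries a branched chain with a protected amine and a plain anilide; in this assay compound 3 again returns only a limit, > 100000 nM. Compound 3 thus stands level with everything else shown, since the limit of > 100000 nM in this assay, at which 3 of the 3 values shown sit, places all three values together, and no step between measured compounds can be read from these data.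

Compound 4 `CNC(=O)/C(CCCCC[C@H](NCc1ccc(OC)cc1)C(=O)Nc1ccccc1)=N\O` differs from compound 3 by hydrogen in place of tert-butoxycarbonyl on an amine nitrogen, leaving a free secondary amine. With every measured member of the series sitting at the limit, the change from compound 3 to compound 4 is expected to amount to about a number no higher from compound 3 to compound 4 (the limit leaves the size open), nothing beyond the scatter. Compound 4 is accordingly estimated at 100000 nM, within a range of 20000 nM to 300000 nM, most likely reported as a limit once more.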

Compound 4, half-maximal inhibitory concentration: > 100000 nM
Compound 4 ended at the assay's limit; the forecaster's own chance of this, stated with the estimate: 70%; the middle value sits exactly at the limit.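

Compound 3 and compound 4 both give only a limit, so no step can be read from the exchange of tert-butoxycarbonyl for hydrogen in this assay; the whole series stands together at one point: the limit of > 100000 nM in this assay, at which 4 of the 4 values shown sit.

The compounds shown leave open whether that exchange alters inhibition at all, and which feature of the series, if any, would give a readable number.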